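A Chlorine Added Where Every Value Is a Limit

This account rests on a few compounds, and the source may have more. Where it says the series, first, only, none or still open, it means among the compounds named here.

Compound 1, `Cc1nc(Nc2cccc(Cl)c2)sc1C(=O)/C=C/c1ccc(Cl)cc1`: in a functional assay on Bel-7402 cells (Homo sapiens) for cytotoxicity, read by MTT assay (a lower number here means a stronger inhibitor, a higher number a weaker inhibitor), compound 1 gives > 25000 nM, which is a limit of the assay and not a number.
Compound 2, `Cc1nc(Nc2ccccc2)sc1C(=O)/C=C/c1ccccc1`: compound 2 gives > 25000 nM, again a limit.
Compound 3, `Cc1nc(Nc2ccc(Cl)c(Cl)c2)sc1C(=O)/C=C/c1ccc(Cl)cc1`: compound 3 gives > 25000 nM, also a limit.

Compound 3 arises from compound 1 by chloro in place of hydrogen on an aromatic carbon, and the step that the two limits leave unreadable from compound 1 to compound 3 cannot be sized, since all values sit at the limit of > 25000 nM in this assay, at which 3 of the 3 values shown sit. The difference between the core of compound 1 and that of compound 2 is not broken down here. Compound 4, `Cc1nc(Nc2ccccc2)sc1C(=O)/C=C/c1ccccc1Cl`, arises from compound 2 by chloro in place of hydrogen on an aromatic carbon, the same kind of change, though the chloro now sits ortho to a large group rather than ortho to a chloro group and para to a large group. Because compound 2 shows only > 25000 nM, the expected step that the limit leaves unreadable from compound 2 to compound 4 is itself an expectation resting on a limit. Compound 4 is estimated at 40000 nM, most likely reported again as a limit.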

Compound 4, half-maximal inhibitory concentration: > 25000 nM
Compound 4: only a limit was reported; the forecaster's own chance of this, stated with the estimate: 85%; the middle value does not contradict the limit.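

No size can be read for the step between compound 2 and compound 4, since both values are limits and not numbers: the limit of > 25000 nM in this assay, at which 4 of the 4 values shown sit.

The compounds shown leave open whether chloro in place of hydrogen changes the result in this assay at all.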